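The source may report more compounds than this note shows. Statements on the series, on what has been measured and on what is new or still open speak of the compounds shown alone.

In a functional assay on MDA-MB-231 cells (Homo sapiens) for antiproliferative activity, with a stated time of 4 days (a higher number here means a weaker inhibitor, a lower number a stronger inhibitor), compound 1 (`CCCCc1ccc2[nH]c(-c3ccc(C(F)(F)F)cc3)c(C=O)c2c1`) gives 33 nM and compound 2 (`CCCCc1ccc2[nH]c(-c3ccc(OC)cc3)c(/C=N/NC(=O)c3ccccc3)c2c1`) gives 32 nM so these two values lie within the scatter of each other and neither stands apart. Compound 3 (`CCCCc1ccc2[nH]c(-c3ccc(C(F)(F)F)cc3)c(/C=N/NC(=O)c3ccccc3)c2c1`) differs from compound 2 in one place: trifluoromethyl in place of methoxy on an aromatic carbon, para to a large group (trifluoromethyl in place of methoxy on an aromatic carbon). Among the compounds with values here, no pair of measured compounds shows this change alone, so the data give no direct size for it. Compound 3 carries the same 4-(trifluoromethyl)phenyl as compound 1, and in this assay compound 1 gives 33 nM despite also differing from compound 3 elsewhere, which gives no reason to expect a large shift in either direction. The expected change is small: a 1.3-fold higher number from compound 2 to compound 3 (0.10 log units; within the scatter) is estimated to stay within the scatter. Compound 3 is expected at 40 nM with 14 nM to 110 nM as the estimated range.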

Compound 3, half-maximal inhibitory concentration: 300 nM
Compound 3: the middle estimate sits 7.5-fold (0.88 log units) below what was measured; measured number above the stated range.
By their numbers in this assay, from the lowest: compounds 2 and 1 (each within the scatter of the next); then compound 3.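

In this assay the change at this position is not neutral when the larger group is present: 4-methoxyphenyl to 4-(trifluoromethyl)phenyl gives a 9.4-fold higher number from compound 2 to compound 3 (0.97 log units; beyond the scatter), so methoxy and trifluoromethyl are not interchangeable here. The 4-(trifluoromethyl)phenyl does not bring this loss on its own, since with that group held fixed, a group of 11 heavy atoms in place of a group of 2 heavy atoms gives a 9.1-fold higher number from compound 1 to compound 3 (0.96 log units; beyond the scatter), and the loss appears only where trifluoromethyl and the larger group occur together. No available data account for either step. On these data alone, whether the methoxy to trifluoromethyl step keeps its size alongside the smaller group of compound 1 remains open. Also open, as far as these compounds go, is how a chlorine, a hydroxyl or an amine at this place would compare with methoxy and trifluoromethyl.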